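The source may hold more compounds than are shown below. What is called first, only, known or untested is meant among the compounds shown, and "the series" means these compounds.

Going by the values given here, in an assay on isolated protein for inhibition of N-acylethanolamine-hydrolyzing acid amidase (Homo sapiens), read by fluorescence, with a stated time of 90 min (on this read-out higher numbers stand for weaker inhibition and lower numbers for stronger inhibition), compound 2 `Fc1cc(-c2ccc(OC(F)(F)F)c(F)c2)ccc1CO[C@H]1C[C@@H](N=C=S)C1` gives 97.1 nM, the lowest of the two numbers measured so far. Among the compounds with values here, compound 1 `CC(C)c1ccc(-c2ccc(CO[C@H]3C[C@@H](N=C=S)C3)c(F)c2)cc1F` gives 227 nM; the single change between the two, trifluoromethoxy in place of isopropyl on an aromatic carbon, yields a 2.3-fold lower number from compound 1 to compound 2 (0.37 log units; beyond the scatter). Compound 3 `CCOc1ccc(-c2ccc(CO[C@H]3C[C@@H](N=C=S)C3)c(F)c2)cc1F` differs from compound 2 by ethyl in place of trifluoromethyl on an oxygen on an aromatic ring. Within the data shown here, no measured step swaps these two groups, so the one step seen so far bears on it only loosely. A somewhat higher number is expected, with a 1.6-fold higher number from compound 2 to compound 3 (0.22 log units; within the scatter) lying close to the scatter. Compound 3 is therefore estimated at 160 nM, within a range of 60 nM to 430 nM.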

Compound 3, half-maximal inhibitory concentration: 69.2 nM
Estimate against measurement, compound 3: 2.3-fold (0.36 log units) above, and the stated range covers the measured number.
By their numbers in this assay, from the lowest: compounds 3 and 2 (each within the scatter of the next); then compound 1.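

In this assay, ethoxy at this aromatic carbon reads the same as trifluoromethoxy within the scatter (a 1.4-fold lower number from compound 2 to compound 3 (0.15 log units; within the scatter)), so in this pair the fluorines of trifluoromethyl are not required to hold the number. Ethoxy in place of isopropyl (a 3.3-fold lower number from compound 1 to compound 3 (0.52 log units; beyond the scatter)) shows that trifluoromethoxy is not the only group here to stand clear of isopropyl. No evidence is available on what lies behind these numbers. From the compounds shown here alone, whether a longer chain such as butoxy, a hydroxyl or an amine at this carbon would keep the number low remains open.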